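A few compounds are considered here, and "the series" means these few. Any claim that something is new, unique, unknown or untested is made for them only; others in the source may bear on it.

Compound 1 `Cc1cc(C)cc(NC(=O)NCCNS(=O)(=O)c2ccc(-c3ccccc3OCc3ccccc3)s2)c1`: > 20000 nM (a limit)
Compound 2 `Cc1ccc(-c2ccsc2S(=O)(=O)NCCNC(=S)Nc2ccc([N+](=O)[O-])cc2)c(Oc2ccc(O)c(O)c2)c1`: 8200 nM
Compound 3 `O=C(NCCNS(=O)(=O)c1cc(-c2ccccc2Oc2ccc(O)c(O)c2)cs1)Nc1cc(C(F)(F)F)cc(C(F)(F)F)c1`: > 50000 nM (a limit)

All three compounds were tested in an ADME assay on HEK-293T cells (Homo sapiens) for cytotoxicity, read by CCK-8 assay, with a stated time of 48 h; on this read-out lower numbers stand for stronger inhibition and higher numbers for weaker inhibition. The entries for compound 1 and compound 3 are limits. Among the compounds with values here, compound 2 is the only one with a number, 8200 nM.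

Compound 4 `Cc1ccc(-c2ccsc2S(=O)(=O)NCCNC(=S)Nc2cccc([N+](=O)[O-])c2)c(Oc2ccc(O)c(O)c2)c1` has the same atoms as compound 2, joined differently: 3-nitrophenyl in place of 4-nitrophenyl on an amide-type nitrogen. It carries 3-nitrophenyl in place of 4-nitrophenyl on an amide-type nitrogen. Within the data shown here, no measured pair shows what such a change does in this assay, so no shift beyond the scatter is expected in either direction. The expected 1.2-fold higher number from compound 2 to compound 4 (0.09 log units; within the scatter) is small. This expectation rests on compound 2 alone, at 8200 nM. Compound 4 is estimated at 10000 nM, with a range of 4000 nM to 25000 nM.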

Compound 4, half-maximal inhibitory concentration: 7900 nM
The estimate for compound 4 lay 1.3-fold (0.10 log units) above the measured number, within the range that was stated.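

In this assay, 3-nitrophenyl in place of 4-nitrophenyl on an amide-type nitrogen gives a 1.0-fold lower number from compound 2 to compound 4 (0.02 log units; within the scatter), and this is the only pair shown that differs in one place. On this nitrogen, the two nitrophenyl groups therefore cannot be told apart in this read-out. Nothing measured here bears on this result.

The compounds shown leave open whether an amine or a carboxylic acid in place of the nitro group would also leave the number unchanged. They also do not show what an unsubstituted phenyl on this nitrogen would give.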